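The compounds below may be only part of what the source reports. "The series", "measured", "known", "first", "only" and "open" are said of these compounds alone.

Measured compounds:
compound 1, `Cc1ccc(S(=O)(=O)/C(=C/c2ccc(C)s2)C(=O)c2ccc(Br)cc2)cc1`: 25000 nM
compound 2, `COc1ccccc1/C=C(\C(=O)c1ccc(Cl)cc1)S(=O)(=O)c1ccc(C)cc1`: 1000 nM

Within the data shown here, in a functional assay on DU-145 cells (Homo sapiens) for inhibition, read by trypan blue exclusion, with a stated time of 96 h (a higher number here means a weaker inhibitor of growth, a lower number a stronger inhibitor of growth), compound 2 gives 1000 nM, the lowest of the two numbers known so far. Compound 1 gives 25000 nM, and the gap between the two lies well beyond the usual scatter. Compound 3 `Cc1ccc(S(=O)(=O)/C(=C/c2ccc(C)s2)C(=O)c2ccc(Cl)cc2)cc1` has not yet been measured. It differs from compound 2 in a single place: 5-methylthiophen-2-yl in place of 2-methoxyphenyl on a double-bonded chain carbon bound to a double-bonded chain carbon. The group that enters is the same one compound 1 carries, and compound 1 stands far above compound 2 in this assay. Among the measured compounds shown here, no step between two measured compounds is available to fix the size of the move, so the expectation rests on the standing of compound 1 alone. Compound 3 is expected to give 12000 nM, within a range of 4000 nM to 30000 nM. The expected step of a 12-fold higher number from compound 2 to compound 3 (1.08 log units; beyond the scatter) is a clear loss of potency, estimated to lie beyond the scatter.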

Compound 3, concentration for 50% growth inhibition: 50000 nM
Estimate against measurement, compound 3: 4.2-fold (0.62 log units) below; measured number outside the range, above it.
By their numbers in this assay, from the lowest: compound 2; then compounds 1 and 3 (each within the scatter of the next).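

Reading this assay, the exchange of 2-methoxyphenyl for 5-methylthiophen-2-yl on a double-bonded chain carbon bound to a double-bonded chain carbon now has a directly measured size, a step of a 50-fold higher number from compound 2 to compound 3 (1.70 log units; beyond the scatter) with nothing else in the structure altered. Chloro in place of bromo on an aromatic carbon, read with the 5-methylthiophen-2-yl group held fixed, gives only a 2.0-fold higher number from compound 1 to compound 3 (0.30 log units; within the scatter) and so cannot be told from the scatter. Among these compounds, then, the large step belongs to the change on the chain carbon and not to the change of halogen, and no measurement at hand explains its size.

As far as these compounds go, it remains open whether a plain phenyl or an unmethylated thiophen-2-yl at this place would stand with compound 2 or with compound 3. From the compounds shown here alone, it is also open whether chloro and bromo stay within the scatter of each other when 2-methoxyphenyl is present.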